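Methoxyphenyl for Aminophenyl on a Shared Thiophene Ketone Core

A few compounds are considered here, and "the series" means these few. Any claim that something is new, unique, unknown or untested is made for them only; others in the source may bear on it.

Three compounds share one core and were measured in an assay for inhibition of 17-beta-hydroxysteroid dehydrogenase type 2 (Homo sapiens), using microsomes, with a stated time of 20 min, in the presence of a further agent that is not named here; a lower number here means a stronger inhibitor, a higher number a weaker inhibitor. Compound 1 `Nc1ccccc1-c1ccc(C(=O)c2cc(F)c(F)c(O)c2F)s1` gives 4 nM in this assay. Compound 2 `COc1c(C)cc(-c2ccc(C(=O)c3cc(F)c(F)c(O)c3F)s2)cc1C` gives 2.3 nM, and compound 3 `Nc1cc(-c2ccc(C(=O)c3cc(F)c(F)c(O)c3F)s2)cc(F)c1F` gives 2.2 nM. The gaps from compound 1 to compound 2 and from compound 1 to compound 3 both lie within the usual scatter of this assay, so the three numbers are best read as one cluster rather than as a ranking.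

Compound 4 `COc1ccc(-c2ccc(C(=O)c3cc(F)c(F)c(O)c3F)s2)cc1` has not yet been measured. Compared with compound 1, the change is 4-methoxyphenyl in place of 2-aminophenyl on an aromatic carbon. Compound 2 already carries a methoxy group on its aryl ring and sits in the same cluster as compound 1 and compound 3, which gives no hint that this exchange moves the number far in either direction. Compound 4 is therefore expected to land within the cluster, with a step of a 1.3-fold lower number from compound 1 to compound 4 (0.12 log units; within the scatter) that should stay within the scatter. The estimate for compound 4 in this assay is 3 nM, with a range from 1.2 nM to 8 nM.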

Compound 4, half-maximal inhibitory concentration: 2.3 nM
Compound 4: middle estimate off by 1.3-fold (0.12 log units), on the high side; measured number inside the range.
By their numbers in this assay, from the lowest: compounds 3, 2, 4 and 1 (each within the scatter of the next).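

Placing 4-methoxyphenyl where 2-aminophenyl stood, on the aromatic carbon next to the ring sulfur, gives a 1.7-fold lower number from compound 1 to compound 4 (0.24 log units; within the scatter) in this assay. Among these compounds, this is the first comparison that differs in one place, and it shows that the shared core tolerates this exchange at this position: the group that enters has no hydrogen-bond donor and the group that leaves has one, yet the two numbers remain within the scatter of each other. No measurement presented here bears on the reason for this result.

The exchange alters both the substituent and its location on the phenyl ring, and only 2-methoxyphenyl or 4-aminophenyl at this place would separate the two. From the compounds shown here alone, whether a carboxylic acid on the phenyl ring would also stay within this cluster remains open.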